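Swapping tert-butyl for ethoxy on the amide aryl ring

The source may hold more compounds than are shown below. What is called first, only, known or untested is meant among the compounds shown, and "the series" means these compounds.

Compound 1 `CC(=O)Nc1cccc(NC(=O)COc2ccc3c(=O)ccoc3c2)c1` gives 2500 nM in an assay on isolated protein for inhibition of Rho-associated protein kinase 1 (Homo sapiens), read by scintillation counting, radiometric assay and 33P incorporation, with a stated time of 40 min, in the presence of a further agent that is not named here; on this read-out higher numbers stand for weaker inhibition and lower numbers for stronger inhibition.
Compound 2 `CCCc1ccc(C(=O)Nc2cccc(NC(=O)COc3ccc4c(=O)ccoc4c3)c2)cc1` gives 143 nM.
Compound 3 `CC(C)(C)c1ccc(C(=O)Nc2cccc(NC(=O)COc3ccc4c(=O)ccoc4c3)c2)cc1` gives 165 nM.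

Compound 3 stands second highest of these three numbers; compound 2 sits within the scatter of it, while compound 1 lies far above. Compound 4 `CCOc1ccc(C(=O)Nc2cccc(NC(=O)COc3ccc4c(=O)ccoc4c3)c2)cc1` differs from compound 3 by ethoxy in place of tert-butyl on an aromatic carbon. Going by the values given here, two measured steps bear on this change: a 17-fold lower number from compound 1 to compound 2 (1.24 log units; beyond the scatter) and a 15-fold lower number from compound 1 to compound 3 (1.18 log units; beyond the scatter) show that placing 4-propylphenyl or 4-(tert-butyl)phenyl on the carbonyl carbon mattered greatly, whereas a 1.2-fold higher number from compound 2 to compound 3 (0.06 log units; within the scatter) shows that exchanging one group for another on that ring changed little. Since compound 4 keeps the phenyl and only exchanges the group on it, the expected step of a 1.3-fold higher number from compound 3 to compound 4 (0.12 log units; within the scatter) is small, perhaps none beyond the scatter. Compound 4 is therefore estimated at 220 nM, within 80 nM to 600 nM.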

Compound 4, half-maximal inhibitory concentration: 17 nM
Compound 4: the middle estimate sits 13-fold (1.11 log units) above what was measured; measured number below the stated range.
By their numbers in this assay, from the lowest: compound 4; then compounds 2 and 3 (each within the scatter of the next); then compound 1.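

Propyl and tert-butyl on this aromatic carbon could not be told apart, yet ethoxy brings a 9.7-fold lower number from compound 3 to compound 4 (0.99 log units; beyond the scatter) and an 8.4-fold lower number from compound 2 to compound 4 (0.92 log units; beyond the scatter), so the group here is not freely interchangeable. Measured against the small methyl of the starting amide, 4-ethoxyphenyl brings a 150-fold lower number from compound 1 to compound 4 (2.17 log units; beyond the scatter), the largest step in this set. No measurement shown here explains this gain.

The compounds shown leave open whether the oxygen alone carries the gain, and how methoxy, a longer propoxy chain or a dimethylamino group on the same carbon would compare.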